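Propyl to isopropylamino on the carbonyl of compound 1

A few compounds are considered here, and "the series" means these few. Any claim that something is new, unique, unknown or untested is made for them only; others in the source may bear on it.

Compound 1 `CCCC(=O)C1=Cc2ccc(OC)cc2OC1c1cc(OC)c(OC)c(OC)c1` carries a propylcarbonyl on its core. In a functional assay for inhibition of nuclear factor NF-kappa-B complex (Homo sapiens) (on this read-out higher numbers stand for weaker inhibition and lower numbers for stronger inhibition), compound 1 gives 11700 nM, the lowest of the two numbers in hand. Compound 3 `COc1ccc2c(c1)OC(c1cc(OC)c(OC)c(OC)c1)C(/C=N/O)=C2` gives 14100 nM; the step of a 1.2-fold higher number from compound 1 to compound 3 (0.08 log units; within the scatter) lies within the scatter, so the two are not told apart. Compound 2 `COc1ccc2c(c1)OC(c1cc(OC)c(OC)c(OC)c1)C(C(N)=O)=C2` returns only a limit of > 50000 nM in this assay. The step of an at least 4.2-fold higher number from compound 1 to compound 2 (0.63 log units; beyond the scatter) is the one that bears on the change now considered, since it also replaces the propyl on the carbonyl carbon.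

Compound 4 `COc1ccc2c(c1)OC(c1cc(OC)c(OC)c(OC)c1)C(C(=O)NC(C)C)=C2` differs from compound 1 by isopropylamino in place of propyl on a carbonyl carbon. The primary amide of compound 2 weakened inhibition at least modestly; the isopropylamino group keeps the carbonyl-bound nitrogen but restores a three-carbon chain. The expected step is therefore upward but smaller than that to compound 2, at a 2.6-fold higher number from compound 1 to compound 4 (0.41 log units; beyond the scatter). Compound 4 is thus estimated at 30000 nM, with a range from 12000 nM to 80000 nM.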

Compound 4, half-maximal inhibitory concentration: > 50000 nM
Compound 4: a limit, no number; the forecaster's own chance of this, stated with the estimate: 35%; at least 1.6-fold (0.22 log units) between middle value and limit.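

In this assay compound 4 reaches only a limit, > 50000 nM. Isopropylamino on the carbonyl carbon thus does not bring back the inhibition lost with amino, for it gives an at least 4.2-fold higher number from compound 1 to compound 4 (0.63 log units; beyond the scatter), and the comparison with the third earlier compound gives an at least 3.5-fold higher number from compound 3 to compound 4 (0.54 log units; beyond the scatter). The step between compound 2 and compound 4 cannot be read, because both stand at the same limit: the limit of > 50000 nM in this assay, at which 2 of the 4 values shown sit.

The compounds shown leave open how far past that limit the two amides lie, and so whether the isopropyl on the amide nitrogen changes anything at all. They also leave open what a dimethylamino group on the carbonyl carbon, or a longer chain in place of the propyl, would do to this read-out.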